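Adding nitro to compound 2: expected solubility

The compounds below may be only part of what the source reports. "The series", "measured", "known", "first", "only" and "open" are said of these compounds alone.

Measured so far in a physicochemical assay for solubility, read by HPLC, at pH 7.4; a higher number here means a more soluble compound, a lower number a less soluble compound:
- compound 1 `CCCCCCCc1[nH]c2ccc([N+](=O)[O-])cc2c(=O)c1C(N)=O`: 15000 nM
- compound 2 `CCCCCCCc1[nH]c2ccccc2c(=O)c1C(=O)NO`: > 200000 nM (a limit of the assay, not a number)

Compound 2 stands at > 200000 nM in this assay. That reading is a limit, so compound 2 has no exact position on the scale.

Compound 3 `CCCCCCCc1[nH]c2ccc([N+](=O)[O-])cc2c(=O)c1C(=O)NO` is compound 2 with nitro in place of hydrogen on an aromatic carbon, the carbon lying on a six-membered aromatic ring of carbon only: nitro in place of hydrogen on an aromatic carbon.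

For the measured compounds named here, no measured step isolates this change, so the expectation rests on a single reference. Compound 1 also carries nitro and gives 15000 nM, a measured number rather than a limit. A downward move in this assay is therefore expected, larger than the usual scatter, though its size is poorly constrained. The expected change is an at least 4.0-fold lower number from compound 2 to compound 3 (0.60 log units; beyond the scatter). A reading that again returns only a limit remains possible.

For compound 3 the estimated value is 50000 nM, with an expected range from 12000 nM to 200000 nM.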

Compound 3, solubility: > 200000 nM
Compound 3 ended at the assay's limit; the forecaster's own chance of this, stated with the estimate: 20%; at least 4.0-fold (0.60 log units) between middle value and limit.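

In this assay compound 3 gives > 200000 nM, a limit of the assay and not a number. The step for nitro in place of hydrogen on an aromatic carbon, from compound 2 to compound 3, cannot be read, because both compounds sit at the same limit: the limit of > 200000 nM in this assay, at which 2 of the 3 values shown sit. For the compounds shown here, compound 1 and compound 3 both carry nitro on this aromatic carbon, so nitro alone does not fix the reading at the level of compound 1, and hydroxy in place of hydrogen on an amide-type nitrogen, the one place in which the two differ, comes with an at least 13-fold higher number from compound 1 to compound 3 (1.12 log units; beyond the scatter), the first readable step.

Still open, going by these compounds, is how far compound 2 and compound 3 lie from each other in this assay, so the size and even the direction of the nitro step remain unknown. Also open, on these data alone, is whether an amine or a carboxylic acid on the same aromatic carbon, or a longer chain on the shared core, would give a number in this assay or again only a limit.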